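The source may report more compounds than this note shows. Statements on the series, on what has been measured and on what is new or still open speak of the compounds shown alone.

Measured so far in a functional assay on HT-29 cells (Homo sapiens) for inhibition, with a stated time of 72 h; on this read-out higher numbers stand for weaker inhibition and lower numbers for stronger inhibition:
Compound 1, `COc1ccc(S(=O)(=O)N2CCc3cccc(-c4ccc([N+](=O)[O-])cc4)c32)cc1`, gives 51.8 nM.
Compound 2, `COc1ccc(S(=O)(=O)N2CCc3cccc(-c4ccc(F)cc4)c32)cc1`, gives 85.5 nM.
Compound 3, `COc1ccc(S(=O)(=O)N2CCc3cccc(-c4ccc(F)c(F)c4)c32)cc1`, gives 57 nM.

Compound 3 stands second highest of the three numbers; its nearest neighbour is compound 1 and its furthest is compound 2, and both gaps lie within the scatter. Compound 4 is `COc1ccc(S(=O)(=O)N2CCc3cccc(-c4cccs4)c32)cc1`. It differs from compound 3 in one place: thiophen-2-yl in place of 3,4-difluorophenyl on an aromatic carbon. Every measured step here also changes the group at this same place on the shared core, and none of them moved the number beyond the scatter: a 1.1-fold higher number from compound 1 to compound 3 (0.04 log units; within the scatter), a 1.7-fold higher number from compound 1 to compound 2 (0.22 log units; within the scatter) and a 1.5-fold lower number from compound 2 to compound 3 (0.18 log units; within the scatter). On that basis no step beyond the scatter is expected, and the estimated change is a 1.4-fold higher number from compound 3 to compound 4 (0.15 log units; within the scatter). Compound 4 is therefore expected to give 80 nM, with a range from 35 nM to 180 nM.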

Compound 4, half-maximal inhibitory concentration: 200 nM
Compound 4: middle estimate off by 2.5-fold (0.40 log units), on the low side; measured number above the stated range.
By their numbers in this assay, from the lowest: compounds 1, 3 and 2 (each within the scatter of the next); then compound 4.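

Until now, changing the group at this place on the shared core had left the number within the scatter, but thiophen-2-yl moves it beyond the scatter against all three earlier groups: a 3.5-fold higher number from compound 3 to compound 4 (0.55 log units; beyond the scatter) and a 2.3-fold higher number from compound 2 to compound 4 (0.37 log units; beyond the scatter) and a 3.9-fold higher number from compound 1 to compound 4 (0.59 log units; beyond the scatter). All three steps are modest and point towards weaker inhibition, so this position does respond to the group it carries. Nothing available explains this weakening.

The compounds shown leave open whether a pyridine ring or thiophen-3-yl at this place would behave like thiophen-2-yl or like the substituted phenyl groups. They also leave open how a phenyl group carrying an amine or a carboxylic acid would fare.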